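A few compounds are considered here, and "the series" means these few. Any claim that something is new, unique, unknown or untested is made for them only; others in the source may bear on it.

Measured so far in a functional assay on PC-3 cells (Homo sapiens) for antiproliferative activity, read by MTT assay, with a stated time of 48 h; on this read-out higher numbers stand for weaker inhibition and lower numbers for stronger inhibition:
Compound 1 `C=C(/C(C)=C/c1ccc(OC)c(O)c1)c1cc(OC)c(OC)c(OC)c1` gives 61 nM.
Compound 2 `CC=C(/C(C)=C/c1ccc(OC)c(O)c1)c1cc(OC)c(OC)c(OC)c1` gives 789 nM.
Compound 3 `CCCC=C(/C(C)=C/c1ccc(OC)c(O)c1)c1cc(OC)c(OC)c(OC)c1` gives 4510 nM.

Compound 1 has the lowest number of the three, which on this read-out means the strongest inhibition; its nearest neighbour is reached by a 13-fold higher number from compound 1 to compound 2 (1.11 log units; beyond the scatter) and the furthest by a 74-fold higher number from compound 1 to compound 3 (1.87 log units; beyond the scatter). Both of these steps lie beyond the scatter, and so does the remaining one, a 5.7-fold higher number from compound 2 to compound 3 (0.76 log units; beyond the scatter). All three measured steps concern the same kind of change, a longer and longer chain placed on a double-bonded chain carbon, and the number rises each time.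

Compound 4 `C=C(/C(C)=C/c1ccc(OC)c(N)c1)c1cc(OC)c(OC)c(OC)c1` differs from compound 1 elsewhere: amino in place of hydroxy on an aromatic carbon. Everything else stays as in compound 1. Going by the values given here, no measured step touches this aromatic carbon, and no measured compound carries an amino group, so the measured steps give no direct guide to the size or direction of this change; they show only that compound 1, with hydrogen on the double-bonded chain carbon, is the strongest starting point. The exchange keeps the counted hydrogen-bond donor and acceptor, which gives some reason to expect the number to stay near that of compound 1 rather than move far. The expected step is a 1.0-fold lower number from compound 1 to compound 4 (0.01 log units; within the scatter). Compound 4 is therefore estimated at 60 nM, with a range from 12 nM to 300 nM.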

Compound 4, half-maximal inhibitory concentration: 457 nM
Compound 4: middle estimate off by 7.6-fold (0.88 log units), on the low side; measured number outside the range, above it.
By their numbers in this assay, from the lowest: compound 1; then compounds 4 and 2 (each within the scatter of the next); then compound 3.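

In this assay, placing amino instead of hydroxy on the aromatic carbon ortho to a methoxy group gives a 7.5-fold higher number from compound 1 to compound 4 (0.87 log units; beyond the scatter). Hydroxy and amino match in every count here, with one heavy atom, one hydrogen-bond donor, one hydrogen-bond acceptor and no net charge, so this step shows that matching counts are not enough to hold the number at this position. Going by these compounds alone, it is also the first measured change on the aromatic ring rather than on the chain, showing that the number responds to changes at this carbon as well, and nothing measured here explains why this exchange raises the number.

The compounds shown leave open whether another group on this carbon, such as fluoro, methylamino or acetamido, would give a number closer to that of the hydroxy compound or further from it. Within the data shown here, they also leave open how the amino exchange would behave on a compound carrying a methyl or propyl group on the double-bonded chain carbon, since it has been seen only with hydrogen there.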